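Cyclopropyl for Isobutyl: What to Expect of Compound 4

This account rests on a few compounds, and the source may have more. Where it says the series, first, only, none or still open, it means among the compounds named here.

Measured so far:
compound 1, `Cc1cc(Oc2ccc(-c3ccn(CCC(C)C)c(=O)c3C#N)cc2)ccn1`: 447 nM
compound 2, `Cc1cc(Oc2ccc(-c3ccn(CC4CC4)c(=O)c3C#N)cc2)ccn1`: 832 nM
compound 3, `Cc1ccc(Oc2ccc(-c3ccn(CCC(C)C)c(=O)c3C#N)cc2)c(C)n1`: 100 nM

In a functional assay on CHO cells for positive allosteric modulation of metabotropic glutamate receptor 2 (Homo sapiens), read by scintillation counting and GTPgammaS binding, with a stated time of 30 min (a lower number here means that less compound is needed, a higher number that more compound is needed for the effect), compound 1 gives 447 nM. Compound 2 differs from it by cyclopropyl in place of isobutyl on a saturated chain carbon bound to an aromatic nitrogen, and the step is a 1.9-fold higher number from compound 1 to compound 2 (0.27 log units; within the scatter), so the two values cannot be told apart. Compound 3 differs from compound 1 by 2,6-dimethylpyridin-3-yl in place of 2-methylpyridin-4-yl on an oxygen on an aromatic ring; here the step is a 4.5-fold lower number from compound 1 to compound 3 (0.65 log units; beyond the scatter), and compound 3 gives 100 nM, the lowest number of the three.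

Compound 4, `Cc1ccc(Oc2ccc(-c3ccn(CC4CC4)c(=O)c3C#N)cc2)c(C)n1`, is not yet measured. It differs from compound 3 by cyclopropyl in place of isobutyl on a saturated chain carbon bound to an aromatic nitrogen, the same change that separates compound 1 from compound 2, made on the core of compound 3 instead of the core of compound 1. Because the earlier step was a 1.9-fold higher number from compound 1 to compound 2 (0.27 log units; within the scatter), a step of similar size is expected here, so for compound 4 the estimate is a 1.9-fold higher number from compound 3 to compound 4 (0.28 log units; within the scatter). Compound 4 is therefore expected to give about 190 nM, with a likely range from 80 nM to 450 nM.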

Compound 4, half-maximal effective concentration: 263 nM
The estimate for compound 4 lay 1.4-fold (0.14 log units) below the measured number; the range from low to high includes it.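

Putting cyclopropyl in place of isobutyl on the core of compound 3 gives a 2.6-fold higher number from compound 3 to compound 4 (0.42 log units; beyond the scatter), and this step matches the one seen on the core of compound 1, even though only one of the two lies beyond the scatter: the same change on two cores in this assay, a 1.9-fold higher number (0.27 log units; within the scatter) from compound 1 to compound 2 and a 2.6-fold higher number (0.42 log units; beyond the scatter) from compound 3 to compound 4, 1.4-fold (0.15 log units) apart, within the scatter of two such steps. Likewise, putting 2,6-dimethylpyridin-3-yl in place of 2-methylpyridin-4-yl gives a 3.2-fold lower number from compound 2 to compound 4 (0.50 log units; beyond the scatter) when cyclopropyl is present, a step that matches the one seen with isobutyl: the same change on two cores in this assay, a 4.5-fold lower number (0.65 log units; beyond the scatter) from compound 1 to compound 3 and a 3.2-fold lower number (0.50 log units; beyond the scatter) from compound 2 to compound 4, 1.4-fold (0.15 log units) apart, within the scatter of two such steps. Across these four compounds, each change therefore carries over from one core to the other with much the same size, but each comparison rests on just one pair of steps, so this does not show that either change would behave the same way on any further core.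

The compounds shown leave open how a longer chain, a cyclobutyl group or an amine would compare with isobutyl and cyclopropyl at this place. They also leave open whether a plain phenyl ring on the oxygen would follow the same pattern as the two pyridines.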